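This account rests on a few compounds, and the source may have more. Where it says the series, first, only, none or still open, it means among the compounds named here.

Working notes on the series. In a functional assay, read by spectrophotometry, in phosphate buffer, with a stated time of 10 min, at pH 6.6 (a lower number here means that less compound is needed, a higher number that more compound is needed for the effect), compound 1 `CCOC(=O)C1=C(C)NC(=O)NC1c1cccc([N+](=O)[O-])c1` gives 339 ug/mL, compound 3 `CCOC(=O)C1=C(C)NC(=O)NC1c1ccc([N+](=O)[O-])cc1` gives 238 ug/mL and compound 2 `COC(=O)C1=C(C)NC(=O)NC1c1ccc([N+](=O)[O-])cc1` gives 170 ug/mL. Compound 1 lies within the usual scatter of both others, so these three values establish no firm order.

Compound 4 `COC(=O)C1=C(C)NC(=O)NC1c1cccc([N+](=O)[O-])c1` has not yet been measured. Its structure differs from that of compound 1 as follows: hydrogen in place of methyl on a saturated chain carbon bound to an oxygen next to a carbonyl group. In words, this is hydrogen in place of methyl on a saturated chain carbon bound to an oxygen next to a carbonyl group, which turns ethoxycarbonyl to methoxycarbonyl.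

Within the data shown here, only one measured step bears on this change: a 1.4-fold higher number from compound 2 to compound 3 (0.15 log units; within the scatter). That step adds the methyl rather than removing it, so its reverse points to a lower number for the change at hand. It comes from a single pair whose structures are not the same as that of compound 1, and it does not exceed the scatter. No shift beyond the scatter is therefore expected in this assay.

The estimate is a 1.4-fold lower number from compound 1 to compound 4 (0.15 log units; within the scatter), a small expected move that would remain within the scatter. For compound 4 the expected value is 240 ug/mL, with an estimated range of 140 ug/mL to 400 ug/mL.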

Compound 4, half-maximal effective concentration: 126 ug/mL
Beside the measured number, compound 4's estimate is 1.9-fold (0.28 log units) above it; the whole stated range lies above it.
By their numbers in this assay, from the lowest: compounds 4, 2, 3 and 1 (each within the scatter of the next, the first and the last beyond it).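

In this assay, among these compounds, the change from ethoxycarbonyl to methoxycarbonyl now gives a step that clears the scatter, a 2.7-fold lower number from compound 1 to compound 4 (0.43 log units; beyond the scatter), whereas the earlier compounds offered only a single step within it. This shows that the group at this position can move the number in this series, although the step is modest and rests on one pair. Read in the same direction, from methoxycarbonyl to ethoxycarbonyl, the change raises the number on both cores, and the two steps cannot be told apart, so the compounds give no firm sign that its size depends on the core: the same change on two cores in this assay, a 1.4-fold higher number (0.15 log units; within the scatter) from compound 2 to compound 3 and a 2.7-fold higher number (0.43 log units; beyond the scatter) from compound 4 to compound 1, 1.9-fold (0.28 log units) apart, within the scatter of two such steps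

What a carboxylic acid or a longer chain, such as propoxycarbonyl, would do at this position stays open, as the compounds shown cover only ethoxycarbonyl and methoxycarbonyl. From the compounds shown here alone, with just two pairs carrying this change, it also stays open whether the higher number with ethoxycarbonyl extends to other cores, and whether the true size of the step lies nearer the smaller or the larger of the two readings.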